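Trifluoromethoxy for Chloro: Expected Tolerability of Compound 4

A few compounds are considered here, and "the series" means these few. Any claim that something is new, unique, unknown or untested is made for them only; others in the source may bear on it.

Measured so far in an ADME assay on Huh-7 cells (Homo sapiens) for cytotoxicity; a lower number here means that less compound is tolerated, a higher number that more compound is tolerated:
compound 1 `Cc1ccccc1-c1nn(-c2ccc(C(F)(F)F)cc2)cc1CNCCN1CCN(C)CC1` gives 11000 nM
compound 2 `CN1CCN(CCCNCc2cn(-c3ccc([N+](=O)[O-])cc3)nc2-c2ccc(Cl)cc2)CC1` gives 3700 nM
compound 3 `Cc1ccccc1-c1nn(-c2ccc(Cl)cc2)cc1CNCCN1CCN(C)CC1` gives 17000 nM

Compound 3 has the highest of the three numbers in this assay. Its value and that of compound 1 lie within the scatter of each other, so no order between them can be read. Compound 2, which differs from compound 3 in several places at once, sits further down, beyond the scatter.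

Compound 4 `Cc1ccccc1-c1nn(-c2ccc(OC(F)(F)F)cc2)cc1CNCCN1CCN(C)CC1` differs from compound 3 in one place: trifluoromethoxy in place of chloro on an aromatic carbon. For the measured compounds named here, the only measured step that bears on this is a 1.5-fold higher number from compound 1 to compound 3 (0.19 log units; within the scatter), which also exchanged one small group for another at the same place on the same ring and stayed within the scatter. On that basis the exchange of chloro for trifluoromethoxy is expected to move the number in this assay little, if at all: the estimated step is a 1.3-fold lower number from compound 3 to compound 4 (0.12 log units; within the scatter), with no direction that can be trusted beyond the scatter. Compound 4 is therefore estimated to give 13000 nM in this assay, with a likely range from 6000 nM to 30000 nM.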

Compound 4, half-maximal cytotoxic concentration: 17000 nM
Compound 4: the middle estimate sits 1.3-fold (0.12 log units) below what was measured; low and high end bracket the measured number.
By their numbers in this assay, from the lowest: compound 2; then compounds 1, 3 and 4 (each within the scatter of the next).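

In this assay the exchange of chloro for trifluoromethoxy gives no change at the digits printed from compound 3 to compound 4 (within the scatter), even though the group entering has five heavy atoms where the one leaving has a single heavy atom, and it brings a hydrogen-bond acceptor that chloro does not count. Compound 4 also makes a third group at this place on the aromatic ring, para to a large group: trifluoromethoxy in place of trifluoromethyl gives a 1.5-fold higher number from compound 1 to compound 4 (0.19 log units; within the scatter), so chloro, trifluoromethyl and trifluoromethoxy all lie within the scatter of one another and no order among them can be read. No measurement at hand accounts for this flat result.

All three groups compared here are halogen-bearing or halogen groups, so the compounds shown leave open whether an amine, a carboxylic acid or a longer alkyl chain at this same place would also stay within the scatter. Going by these compounds, compound 2 differs from the others in several places at once, so its lower number cannot be traced to any single change, and the part played by the rest of the molecule remains open.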